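A few compounds are considered here, and "the series" means these few. Any claim that something is new, unique, unknown or untested is made for them only; others in the source may bear on it.

Compound 1 `CC(=O)N(CC(C1CCCCC1)N1CCN(C(=O)[C@@H]2CN(C(C)(C)C)C[C@H]2c2ccc(F)cc2F)CC1)C(C)C` carries an acetyl group on the amine nitrogen of the side chain, and in a functional assay on CHO cells for agonist activity at Melanocyte-stimulating hormone receptor (Homo sapiens), read by cAMP accumulation (a lower number here means that less compound is needed, a higher number that more compound is needed for the effect), compound 1 gives 890 nM. Compound 2 `CC(C)N(CC(C1CCCCC1)N1CCN(C(=O)[C@@H]2CN(C(C)(C)C)C[C@H]2c2ccc(F)cc2F)CC1)S(C)(=O)=O` is its methylsulfonyl counterpart; in this assay compound 2 gives 540 nM. For the measured compounds named here, the change a 1.6-fold lower number from compound 1 to compound 2 (0.22 log units; within the scatter) is within the scatter, so on the two numbers so far compound 2 stands with the lower one, with compound 1 within the scatter of it. Compound 3 `CC(C)N(CC(C1CCCCC1)N1CCN(C(=O)[C@@H]2CN(C(C)(C)C)C[C@H]2c2ccc(F)cc2F)CC1)C(=O)c1cccnn1` alters the same position: (pyridazin-3-yl)carbonyl in place of methylsulfonyl on an amine nitrogen. Going by the values given here, the only measured step that bears on this is the one from compound 1 to compound 2, which exchanged the substituent on this nitrogen without a shift beyond the scatter. Since the step of a 1.6-fold lower number from compound 1 to compound 2 (0.22 log units; within the scatter) was small, the expectation for compound 3 in this assay is a number near that of compound 2, around 700 nM, with a range from 200 nM to 2500 nM. The step this implies, a 1.3-fold higher number from compound 2 to compound 3 (0.11 log units; within the scatter), is an estimate, and the larger group entering leaves the range wide.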

Compound 3, half-maximal effective concentration: 1200 nM
Compound 3: middle estimate off by 1.7-fold (0.23 log units), on the low side, within the range that was stated.
By their numbers in this assay, from the lowest: compounds 2, 1 and 3 (each within the scatter of the next, the first and the last beyond it).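

For the compounds shown here, at this nitrogen the substituent does register in this assay: a 2.2-fold higher number from compound 2 to compound 3 (0.35 log units; beyond the scatter) is the first step here to pass beyond the scatter, though only modestly. The same (pyridazin-3-yl)carbonyl group set against the acetyl group gives a 1.3-fold higher number from compound 1 to compound 3 (0.13 log units; within the scatter), so an aromatic ring on the carbonyl carbon separates compound 3 clearly from the methylsulfonyl compound 2 but not from the acetyl compound 1, and the three values span a narrow band. Nothing at hand explains the gap between compound 2 and compound 3.

Three groups on one nitrogen cannot show whether this gap belongs to the sulfonyl group as such or to the pyridazine ring. A benzoyl group, a larger alkylsulfonyl group such as phenylsulfonyl, or a plain hydrogen on this nitrogen would each bear on that question, and the compounds shown leave it open.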